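The source may report more compounds than this note shows. Statements on the series, on what has been measured and on what is new or still open speak of the compounds shown alone.

In a functional assay on HT-22 cells (Mus musculus), read by MTT assay, with a stated time of 24 h (on this read-out higher numbers stand for an effect only at larger amounts of compound and lower numbers for an effect already at smaller amounts), compound 1 `Cc1cc(O)c(C(=O)/C=C/c2ccc(O)c(O)c2)cc1C` gives 50 nM and compound 3 `CC(C)Oc1cc(-c2ccc(O)c(O)c2)nc2ccccc12` gives 20 nM. Compound 2 `CCOc1ccc(-c2cc(=O)c3cc(C)c(C)cc3o2)cc1OCC` stands apart from these two, as compound 2 is reported as "not active" (no number reported). It therefore has no single number and cannot be placed on the same scale by size.

Compound 4 `CCOc1ccc(-c2oc3cc(C)c(C)cc3c(=O)c2O)cc1OCC` keeps the two ethoxy groups and the two methyl groups of compound 2. Within the data shown here, the one structural change is hydroxy in place of hydrogen on an aromatic carbon, which is a hydroxy in place of hydrogen on an aromatic carbon. Among the measured compounds shown here, no measured pair in this small set shows the effect of that change, so the expectation rests on the structures and on the three results alone.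

The expected step in this assay runs from no reported number toward a measurable effect, meaning a move to the active side. Its size cannot be stated, as compound 2 provides no starting value. Compound 4 may also remain without a number, and that outcome is a serious possibility. If a number is obtained, it is expected to be weaker than the value of compound 3 at 20 nM.

For compound 4, the half-maximal effective concentration is estimated at 1000 nM, within an expected range of 100 nM to 10000 nM.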

Compound 4, half-maximal effective concentration: 500 nM
Compound 4: middle estimate off by 2.0-fold (0.30 log units), on the high side, and the stated range covers the measured number.
By their numbers in this assay, from the lowest: compound 3; then compound 1; then compound 4.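

No step can be read from compound 2 to compound 4: in this assay compound 4 gives 500 nM while compound 2 has no number. The compounds shown leave open how large the effect of hydroxy in place of hydrogen is, and no evidence given here bears on this result.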